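Working notes: compound 3 to compound 4

The source may report more compounds than this note shows. Statements on the series, on what has been measured and on what is new or still open speak of the compounds shown alone.

Values in a functional assay on CEM-SS cells (Homo sapiens) for cytotoxicity; on this read-out higher numbers stand for weaker inhibition and lower numbers for stronger inhibition:
- Compound 1 `CC(C)(C)c1ccc(Cn2c(N)nc3cc(Cl)c(Cl)cc32)cc1`: 27000 nM
- Compound 2 `Cc1cccc(Cn2c(Cl)nc3cc(Cl)c(Cl)cc32)c1`: > 100000 nM
- Compound 3 `Clc1cc2nc(Br)n(Cc3ccccc3)c2cc1Cl`: > 100000 nM

Compound 3 stands at > 100000 nM, which is a limit of the assay and not a number. Compound 2, at > 100000 nM, is also a limit. Together they make up (the limit of > 100000 nM in this assay, at which 2 of the 3 values shown sit). Among the compounds with values here, compound 1 gives the only number, 27000 nM.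

Compound 4 `COc1ccc(Cn2c(Br)nc3cc(Cl)c(Cl)cc32)cc1` has methoxy in place of hydrogen on an aromatic carbon of a six-membered aromatic ring of carbon only, para to a large group (methoxy in place of hydrogen on an aromatic carbon). Within the data shown here, no measured step covers this change. In this assay, no step beyond the scatter is expected, in either direction, and another limit is the likeliest report. The estimated step is a number no higher from compound 3 to compound 4 (the limit leaves the size open). Compound 4 is expected at 100000 nM, with an estimated range of 40000 nM to 200000 nM.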

Compound 4, half-maximal inhibitory concentration: 60000 nM
Compound 4: middle estimate off by 1.7-fold (0.22 log units), on the high side; the range from low to high includes it.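

In this assay, methoxy in place of hydrogen on an aromatic carbon, para to a large group, gives an at least 1.6-fold lower number from compound 3 to compound 4 (0.22 log units; that floor lies within the scatter). This floor does not establish a real change, but with methoxy at this position, compound 4 gives a number rather than a limit. The true size of the step stays open because compound 3 carries only a limit: the limit of > 100000 nM in this assay, at which 2 of the 4 values shown sit.

The compounds shown do not tell how a hydroxyl, an amine or a longer chain on the same carbon would read out in this assay.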